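A few compounds are considered here, and "the series" means these few. Any claim that something is new, unique, unknown or untested is made for them only; others in the source may bear on it.

Working notes on the series. Compound 1 `Oc1cc(C(F)(F)F)ccc1-c1nc(-c2ccccc2O)n(-c2ccc(Cl)cc2)n1` gives 68% in a functional assay on PC-12 cells (Rattus norvegicus) for cytotoxicity, read by MTT assay, with stated times of 2 h and 24 h, tested at 1 uM; a higher number here means a stronger effect of the compound at the concentration tested, a lower number a weaker effect. Compound 2 `Oc1cc(C(F)(F)F)ccc1-c1nc(-c2ccccc2O)n(-c2ccc(C(F)(F)F)cc2)n1` gives 70.7% in this assay, and compound 3 `Oc1cc(C(F)(F)F)ccc1-c1nc(-c2ccccc2O)n(-c2ccc(OC(F)(F)F)cc2)n1` gives 65.5% there, the lowest of the three numbers, though both gaps to it are within the scatter: a number 2.5 percentage points lower from compound 1 to compound 3 (within the scatter) and a number 5.2 percentage points lower from compound 2 to compound 3 (within the scatter), with a number 2.7 percentage points higher from compound 1 to compound 2 (within the scatter) also within it. Compound 4 `Oc1cc(C(F)(F)F)ccc1-c1nc(-c2ccccc2O)n(-c2ccc(F)cc2F)n1` differs from compound 3 as follows: 2,4-difluorophenyl in place of 4-(trifluoromethoxy)phenyl on an aromatic nitrogen. The three measured steps all exchange one group on an aromatic carbon of that same phenyl ring, and none moved beyond the scatter, so for this exchange no step beyond the scatter is expected either. The expected step from compound 3 is a number 1.5 percentage points higher from compound 3 to compound 4 (within the scatter). Compound 4 is accordingly estimated at 67%, with a range of 55% to 78%.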

Compound 4, a percentage reported as activity, at one concentration (the size of the read-out at that concentration, not a potency): 65.9%
Estimate against measurement, compound 4: 1.1 percentage points above; the measured number falls inside the stated range.
By their numbers in this assay, from the lowest: compounds 3, 4, 1 and 2 (each within the scatter of the next).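

Earlier steps exchanged one group on an aromatic carbon of the same phenyl ring, whereas compound 4 changes the substituent on the aromatic nitrogen to 2,4-difluorophenyl, and this assay gives a number 0.4 percentage points higher from compound 3 to compound 4 (within the scatter) with a number 4.8 percentage points lower from compound 2 to compound 4 (within the scatter) and a number 2.1 percentage points lower from compound 1 to compound 4 (within the scatter) as its other two steps. The read-out at this position therefore stays within the scatter across all four aryl groups shown, including the one that carries two fluorines. Nothing available bears on this result. Open, as far as these compounds go, is whether an aminomethyl or carboxylic acid group on this ring, or a longer alkyl chain in place of the ring, would move the number beyond the scatter.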